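Aryl exchange on the ester series: compound 2 to compound 3

This account rests on a few compounds, and the source may have more. Where it says the series, first, only, none or still open, it means among the compounds named here.

Measured compounds:
compound 1, `CCOC(=O)CC1C(C#N)=C(N)Oc2ccc(-c3cc(OC)cc(OC)c3)cc21`: 19600 nM
compound 2, `CCOC(=O)CC1C(C(=O)OCC)=C(N)Oc2ccc(-c3ccccc3F)cc21`: 73000 nM

Among the compounds with values here, the two measured members share a core that differs at the substituent on the aryl ring and at the group on the enamine carbon. In a functional assay on HL-60 cells (Homo sapiens) for cytotoxicity, read by CellTiter-Blue, with a stated time of 48 h (a higher number here means a weaker inhibitor, a lower number a stronger inhibitor), compound 1 gives 19600 nM, and in this assay compound 2 gives 73000 nM. Compound 2 therefore stands at the higher of the two numbers, and its gap to compound 1 lies beyond the scatter. Within the data shown here, since compound 1 and compound 2 differ in two places, no single step between measured compounds can be isolated.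

Compound 3, `CCOC(=O)CC1C(C(=O)OCC)=C(N)Oc2ccc(-c3ccc(N)cc3)cc21`, keeps the ester of compound 2 and changes only the aryl group: 4-aminophenyl in place of 2-fluorophenyl on an aromatic carbon.

Among the measured compounds shown here, no measured pair shows what this change does. The expectation for this assay is a step of modest size, leaning toward a lower number, but one that may also fall within the scatter. Compound 3 is estimated at 45000 nM, with a range from 15000 nM to 140000 nM, which corresponds to an expected step of a 1.6-fold lower number from compound 2 to compound 3 (0.21 log units; within the scatter).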

Compound 3, half-maximal inhibitory concentration: 22300 nM
Estimate against measurement, compound 3: 2.0-fold (0.30 log units) above, within the range that was stated.
By their numbers in this assay, from the lowest: compounds 1 and 3 (each within the scatter of the next); then compound 2.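

In this assay, within the data shown here, with the ester of compound 2 held fixed, 4-aminophenyl in place of 2-fluorophenyl gives a 3.3-fold lower number from compound 2 to compound 3 (0.52 log units; beyond the scatter), the first single-place step. It shows that the number responds to the aryl group alone at this aromatic carbon, para to a fused ring in the shared core, since the earlier pair changed the enamine-carbon group at the same time. The step still bundles two differences, the loss of fluorine and the gain of an amine at another place on the phenyl ring, and no measurement here explains it.

The compounds shown do not separate these two differences: a plain phenyl group, with neither fluorine nor amine, would give the reference point that both compound 2 and compound 3 lack, and a hydroxyl or a carboxylic acid in the place of the amine would show whether the step is specific to the amine. The nitrile of compound 1 also remains unpaired, so its contribution relative to the ethyl ester cannot be read on any shared aryl group.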